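The source may hold more compounds than are shown below. What is called first, only, known or untested is meant among the compounds shown, and "the series" means these compounds.

Working notes on the series. Compound 1 `COc1ccc(/C=C/C(=O)c2ccccc2-c2cccc(F)c2)cc1` is the reference for the first pair; in a functional assay on HepG2 cells (Homo sapiens) for antiproliferative activity, read by sulforhodamine B assay, with a stated time of 48 h (on this read-out higher numbers stand for weaker inhibition and lower numbers for stronger inhibition), compound 1 gives 110 nM. Compound 2 `COc1ccc(/C=C/C(=O)c2ccccc2-c2cccc(F)c2)cc1OC` carries the change methoxy in place of hydrogen on an aromatic carbon and in this assay compound 2 gives 150 nM, a step of a 1.4-fold higher number from compound 1 to compound 2 (0.13 log units; within the scatter).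

Compound 3 `COc1ccc(C(=O)/C=C/c2ccccc2-c2ccc(F)cc2)cc1` is built on a different core; how its core differs from that of compound 1 is not broken down here. In this assay compound 3 gives 6300 nM, which stands well apart from compounds 1 and 2.

Compound 4 `COc1ccc(C(=O)/C=C/c2ccccc2-c2ccc(F)cc2)cc1OC` applies the same change to compound 3, (methoxy in place of hydrogen on an aromatic carbon), with the surroundings of the place matching those in the first pair word for word. The step from compound 3 to compound 4 is expected to be small, a 1.3-fold higher number from compound 3 to compound 4 (0.10 log units; within the scatter), resting on the step of a 1.4-fold higher number from compound 1 to compound 2 (0.13 log units; within the scatter) seen for the same change. Compound 4 is therefore estimated at 8000 nM, between 3000 nM and 25000 nM.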

Compound 4, half-maximal inhibitory concentration: 6600 nM
The estimate for compound 4 lay 1.2-fold (0.08 log units) above the measured number; measured number inside the range.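

On the core of compound 3, methoxy in place of hydrogen on an aromatic carbon gives in this assay a 1.0-fold higher number from compound 3 to compound 4 (0.02 log units; within the scatter). Set beside the earlier step, the change carries across the two cores without a difference that can be told apart: the same change on two cores in this assay, a 1.4-fold higher number (0.13 log units; within the scatter) from compound 1 to compound 2 and a 1.0-fold higher number (0.02 log units; within the scatter) from compound 3 to compound 4, 1.3-fold (0.11 log units) apart, within the scatter of two such steps. This agreement rests on a single pair per core at one kind of place, so it supports carrying the change between these two cores only and gives no reason for the result, nor any account of the wide gap between the cores.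

As far as these compounds go, whether an ethoxy group, a hydroxyl or an amine at the same place would behave like methoxy remains open. From the compounds shown here alone, whether the step would hold on any third core also remains open.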